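Trimming the long chain of compound 2

The source may report more compounds than this note shows. Statements on the series, on what has been measured and on what is new or still open speak of the compounds shown alone.

Compound 1 `CCCCCCCC/C=C\CCCCCCCC(=O)O[C@H]1[C@H](O)[C@H](n2ccc(N)nc2=O)O[C@@H]1CO` gives 0.06 ug/mL
Compound 2 `CCCCCCCC/C=C/CCCCCCCC(=O)O[C@H]1[C@H](O)[C@H](n2ccc(N)nc2=O)O[C@@H]1CO` gives 0.05 ug/mL

In a functional assay on HeLa cells (Homo sapiens) for cytotoxicity, read by cell counting, with a stated time of 48 h (a higher number here means that more compound is needed for the effect, a lower number that less compound is needed), compound 2 gives 0.05 ug/mL and sits within the scatter of compound 1. Compound 3 `CCCCCCCCC(=O)O[C@H]1[C@H](O)[C@H](n2ccc(N)nc2=O)O[C@@H]1CO` carries one change (one carbon atom in place of a group of 10 heavy atoms (10 carbon; no ring), on a saturated chain carbon, seven bonds along the chain from a carbonyl carbon) on a saturated chain carbon, seven bonds along the chain from a carbonyl carbon. Among the compounds with values here, the only measured step (a 1.2-fold lower number from compound 1 to compound 2 (0.08 log units; within the scatter)) alters just the configuration of the double bond, so it offers no guide to shortening the chain. A modest move to a higher number is expected, with wide uncertainty. The expected change is a 2.0-fold higher number from compound 2 to compound 3 (0.30 log units; within the scatter) as a rough estimate. In this assay compound 3 is estimated at 0.1 ug/mL (expected range 0.02 ug/mL to 0.6 ug/mL).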

Compound 3, concentration for half-maximal effect: 0.05 ug/mL
The estimate for compound 3 lay 2.0-fold (0.30 log units) above the measured number; measured number inside the range.
By their numbers in this assay, from the lowest: compounds 2, 3 and 1 (each within the scatter of the next).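

Earlier compounds varied only the configuration of the double bond; compound 3 shows that the whole dec-1-en-1-yl group can give way to methyl, on a saturated chain carbon, seven bonds along the chain from a carbonyl carbon. In this assay this swap gives no change at the digits printed from compound 2 to compound 3 (within the scatter), and likewise a 1.2-fold lower number from compound 1 to compound 3 (0.08 log units; within the scatter). Nothing measured here explains this tolerance.

Still open, on these data alone, is whether a carboxylic acid or an amine in place of that methyl would leave the number within the scatter. As far as these compounds go, a longer chain at this place is equally open.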